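The compounds below may be only part of what the source reports. "The series", "measured", "known", "first", "only" and "open" are said of these compounds alone.

Values so far in a functional assay on RAW264.7 cells (Mus musculus) for inhibition, read by Griess assay, with stated times of 2 h and 24 h (on this read-out lower numbers stand for stronger inhibition and higher numbers for weaker inhibition), are these
- compound 1 `CCn1cc(COc2cc(O)c3c(c2)O[C@H](c2ccc(OC)c(O)c2)C/C3=N\O)nn1` gives 3140 nM
- compound 2 `COc1ccc([C@@H]2C/C(=N\O)c3c(O)cc(OCc4cn(Cc5ccccc5F)nn4)cc3O2)cc1O` gives 5710 nM
- compound 3 `COc1ccc([C@@H]2CC(=O)c3c(O)cc(OCc4cn(Cc5cccc(C#N)c5)nn4)cc3O2)cc1O` gives 18000 nM

Compound 2 stands within the scatter of compound 1, while compound 3 has a higher number, beyond the scatter from compound 2. Compound 3 differs from compound 2 in more than one place, so it offers no single step to reason from.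

The next compound is compound 4 `COc1ccc([C@@H]2C/C(=N\O)c3c(O)cc(OCc4cn(C5CCCC5)nn4)cc3O2)cc1O`, which carries cyclopentyl in place of 2-fluorobenzyl on an aromatic nitrogen. Among the compounds with values here, the counted difference is cyclopentyl in place of 2-fluorobenzyl on an aromatic nitrogen and it is the only change from compound 2.

Within the data shown here, one measured step touches the group on this aromatic nitrogen: a 1.8-fold higher number from compound 1 to compound 2 (0.26 log units; within the scatter) is within the scatter. Among the measured compounds shown here, no compound measured so far carries cyclopentyl, so that single step is a thin guide. For the measured compounds named here, with it as the only evidence, no step beyond the scatter is expected in this assay, and no direction is favoured with any confidence.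

For compound 4 the estimated value is 4500 nM, with an expected range from 2000 nM to 10000 nM as the outer ends. The expected step is a 1.3-fold lower number from compound 2 to compound 4 (0.10 log units; within the scatter) and it stays within the scatter.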

Compound 4, half-maximal inhibitory concentration: 6880 nM
Compound 4: middle estimate off by 1.5-fold (0.18 log units), on the low side; low and high end bracket the measured number.
By their numbers in this assay, from the lowest: compounds 1, 2 and 4 (each within the scatter of the next, the first and the last beyond it); then compound 3.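

In this assay, swapping the 2-fluorobenzyl on the aromatic nitrogen of the five-membered aromatic ring for cyclopentyl gives a 1.2-fold higher number from compound 2 to compound 4 (0.08 log units; within the scatter), so a six-membered aromatic ring of carbon only can give way to a five-membered non-aromatic ring of carbon only at this position with no step beyond the scatter. Cyclopentyl in place of ethyl gives a 2.2-fold higher number from compound 1 to compound 4 (0.34 log units; beyond the scatter), the only step at this position so far that lies beyond the scatter, and it is modest, while compound 2 sits within the scatter of both compound 1 and compound 4, as a 1.8-fold higher number from compound 1 to compound 2 (0.26 log units; within the scatter) shows for the ethyl side; ethyl, 2-fluorobenzyl and cyclopentyl therefore span a narrow band on this read-out. No measurement is at hand that would explain this narrow band or the modest step.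

Still open, from the compounds shown here alone, is whether this position stays as flat with a group of a different kind on the aromatic nitrogen, such as an amine, a carboxylic acid or a longer chain. Compound 3 differs from the others in more than one place, so it cannot settle this.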